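The source may hold more compounds than are shown below. What is called first, only, known or untested is meant among the compounds shown, and "the series" means these compounds.

Measured compounds:
compound 1 `CCOC(=O)Cc1n[nH]c(NC(=O)c2ccccc2)n1` — 26.8%
compound 2 `CCOC(=O)Cc1n[nH]c(NC(=O)c2ccc(Cl)cc2)n1` — 31.1%

Both compounds were tested in a functional assay on the whole organism (strain albino) for inhibition, with Rattus norvegicus as the target, read by paw edema, with stated times of 30 min and 1 h, at a dose of 5 mg/kg by the oral route; a higher number here means more inhibition at the dose given (going by the name of the read-out), a lower number less inhibition. Within the data shown here, compound 2 stands at one end of the two numbers, yet the only step between them, a number 4.3 percentage points higher from compound 1 to compound 2 (within the scatter), lies within the scatter of this assay, so the two compounds cannot be told apart on these data.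

Compound 3 `CCOC(=O)Cc1n[nH]c(NC(=O)c2ccc(Br)cc2)n1` is the next compound. Its difference from compound 2 is bromo in place of chloro on an aromatic carbon. Among the measured compounds shown here, the one measured step, a number 4.3 percentage points higher from compound 1 to compound 2 (within the scatter), put a chloro in place of hydrogen and changed the read-out by less than the scatter. For the measured compounds named here, no measured step exchanges one halogen for another, so nothing here points to a shift in either direction. The step from compound 2 to compound 3 is therefore expected to stay within the scatter: a number 0.9 percentage points higher from compound 2 to compound 3 (within the scatter). For compound 3 the estimated inhibition is 32%, with a range from 22% to 42%.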

Compound 3, a percentage reported as inhibition, in the whole organism at one dose (the size of the read-out at that dose, not a potency): 31.3%
The estimate for compound 3 lay 0.7 percentage points above the measured number, within the range that was stated.
By their numbers in this assay, from the lowest: compounds 1, 2 and 3 (each within the scatter of the next).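

In this assay, bromo in place of chloro on the aromatic carbon para to a large group gives a number 0.2 percentage points higher from compound 2 to compound 3 (within the scatter), so swapping one halogen for the other leaves no readable mark on this read-out. Bromo in place of hydrogen on the same carbon gives a number 4.5 percentage points higher from compound 1 to compound 3 (within the scatter), so, like the chloro of compound 2, the bromo of compound 3 cannot be told apart from the hydrogen of compound 1. Nothing available explains why the three compounds lie so close together.

Only hydrogen, chloro and bromo are shown on this carbon, so it remains open whether any group placed here can move the read-out beyond the scatter. An amine or a carboxylic acid on the same carbon would test this.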